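Solubility notes: compound 4 against compound 1

The source may report more compounds than this note shows. Statements on the series, on what has been measured and on what is new or still open speak of the compounds shown alone.

Within the data shown here, compound 1 `COc1ccc(F)cc1CNCCCNc1ccnc2cc(Cc3ccc(F)cc3Cl)ccc12` is one of three compounds measured in a physicochemical assay for solubility, with a stated time of 18 h, at pH 7.4 (a lower number here means a less soluble compound, a higher number a more soluble compound), where compound 1 gives 4200 nM. Compound 2 `Fc1ccc(Cc2ccc3c(NCCCNCc4ccco4)ccnc3c2)c(Cl)c1` gives 4200 nM, and the step of no change at the digits printed from compound 1 to compound 2 (within the scatter) leaves the number unchanged within the scatter. Compound 3 `c1ccc(-c2ccc3c(NCCCNCc4ccco4)ccnc3c2)cc1` gives 32000 nM; the step of a 7.6-fold higher number from compound 2 to compound 3 (0.88 log units; beyond the scatter) is the only movement beyond the scatter in the set, so compound 1 and compound 2 together hold the lowest numbers shown, with compound 3 the furthest from compound 1.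

Compound 4 `COc1ccc(F)cc1CNCCCNc1ccnc2cc(Cc3cc(C)cc(C)c3)ccc12` differs from compound 1 by 3,5-dimethylphenyl in place of 2-chloro-4-fluorophenyl on a saturated chain carbon bound to an aromatic carbon. Among the measured compounds shown here, no measured step swaps one substituted phenyl for another at this place: the step from compound 2 to compound 3 removes the whole 2-chloro-4-fluorobenzyl for phenyl, and the step from compound 1 to compound 2 changes the other end of the chain without moving the number. The change to compound 4 keeps the benzyl and its ring size, so the expected step of a 1.1-fold lower number from compound 1 to compound 4 (0.02 log units; within the scatter) is small and uncertain in direction. Compound 4 is estimated at 4000 nM, within 1500 nM to 11000 nM.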

Compound 4, solubility: 4200 nM
Estimate against measurement, compound 4: 1.1-fold (0.02 log units) below, and the stated range covers the measured number.
By their numbers in this assay, from the lowest: compounds 1, 2 and 4 (each within the scatter of the next); then compound 3.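

In this assay the change to 3,5-dimethylphenyl in place of 2-chloro-4-fluorophenyl reads as no change at the digits printed from compound 1 to compound 4 (within the scatter), so two differently substituted benzyl groups give the same number on the core of compound 1. The earlier step of a 7.6-fold higher number from compound 2 to compound 3 (0.88 log units; beyond the scatter) replaced the whole benzyl with phenyl, whereas this result shows that, with the benzyl kept, exchanging chlorine and fluorine for two methyl groups leaves the number level. No accompanying measurement bears on the reason for this result.

Still open, on these data alone, is whether a ring substituent of another kind, such as a carboxylic acid or an amine on this benzyl ring, would separate from compound 1 in this read-out. Also open, as far as these compounds go, is whether 3,5-dimethylbenzyl would read the same with furan-2-yl at the other end of the chain.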